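This account rests on a few compounds, and the source may have more. Where it says the series, first, only, none or still open, it means among the compounds named here.

Compound 1 `O=C(CCCCCCc1cccnc1)c1ncc(-c2ccccn2)o1`: 32 nM
Compound 2 `Nc1cccc(CCCCCCC(=O)c2ncc(-c3ccccn3)o2)c1`: 30 nM

Both were measured in an assay for inhibition of Fatty-acid amide hydrolase 1 (Rattus norvegicus); on this read-out higher numbers stand for weaker inhibition and lower numbers for stronger inhibition. Compound 2 stands lowest of the two numbers, at 30 nM, with compound 1 at 32 nM; the step of a 1.1-fold lower number from compound 1 to compound 2 (0.03 log units; within the scatter) lies within the scatter, so the two cannot be told apart. Compound 3 `CN(CCCCCC(=O)c1ncc(-c2ccccn2)o1)c1ccccc1` has not yet been measured. It differs from compound 2 in this way: methyl(phenyl)amino in place of 3-aminobenzyl on a saturated chain carbon, five bonds along the chain from a carbonyl carbon. Going by the values given here, the only measured step, a 1.1-fold lower number from compound 1 to compound 2 (0.03 log units; within the scatter), bears on it just loosely: that step exchanged one ring for another at the same place on the chain and showed nothing beyond the scatter, whereas here the two compounds hold the same atoms joined differently, and the attachment moves from six to five bonds along the chain from the carbonyl carbon. Among the compounds with values here, no measured step covers such a rearrangement. A modest weakening is expected, a 2.0-fold higher number from compound 2 to compound 3 (0.30 log units; within the scatter). For compound 3 the estimate in this assay is 60 nM, with a range from 15 nM to 250 nM.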

Compound 3, inhibition constant: 40 nM
Compound 3: middle estimate off by 1.5-fold (0.18 log units), on the high side; measured number inside the range.
By their numbers in this assay, from the lowest: compounds 2, 1 and 3 (each within the scatter of the next).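

In this assay, methyl(phenyl)amino in place of 3-aminobenzyl gives a 1.3-fold higher number from compound 2 to compound 3 (0.12 log units; within the scatter), and the same group in place of (pyridin-3-yl)methyl gives a 1.3-fold higher number from compound 1 to compound 3 (0.10 log units; within the scatter), so compound 3 cannot be told apart from either earlier compound. This place on the chain therefore tolerates a ring joined through a methyl-bearing nitrogen as well as one joined through carbon, and methyl(phenyl)amino does so with no hydrogen-bond donor, unlike 3-aminobenzyl. No measurement here offers an explanation for this tolerance.

The compounds shown leave open how a chain ending without a ring, such as one ending in a carboxylic acid, would read in this assay. They also leave open what a longer chain, or a chlorine on the phenyl ring of methyl(phenyl)amino, would do.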